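From thiophen-2-yl to 4-phenylphenyl on the carbonyl carbon

This account rests on a few compounds, and the source may have more. Where it says the series, first, only, none or still open, it means among the compounds named here.

Compound 3 `COc1cc(-c2nnc3n2NC(c2ccco2)C(C(=O)c2cccs2)S3)cc(OC)c1OC` carries a thiophen-2-yl group on the carbonyl carbon. In a functional assay on HepG2 cells (Homo sapiens) for cytotoxicity, read by MTT assay, with a stated time of 48 h (on this read-out lower numbers stand for stronger inhibition and higher numbers for weaker inhibition), compound 3 gives 64100 nM, the highest of the two numbers recorded. Its nearest neighbour is compound 1 `COc1cc(-c2nnc3n2NC(c2ccco2)C(C(=O)c2ccc(F)c(F)c2)S3)cc(OC)c1OC`, which in this assay gives 52400 nM; the step of a 1.2-fold higher number from compound 1 to compound 3 (0.09 log units; within the scatter). Compound 2 `COc1ccc(C(=O)C2Sc3nnc(-c4cc(OC)c(OC)c(OC)c4)n3NC2c2ccco2)cc1` gives > 100000 nM, which is a limit of the assay rather than a number (the limit of > 100000 nM in this assay, at which 1 of the 3 values shown sits). The step of an at least 1.5-fold lower number from compound 2 to compound 3 (0.19 log units; that floor lies within the scatter). Compound 4 `COc1cc(-c2nnc3n2NC(c2ccco2)C(C(=O)c2ccc(-c4ccccc4)cc2)S3)cc(OC)c1OC` differs from compound 3 by 4-phenylphenyl in place of thiophen-2-yl on a carbonyl carbon. For the measured compounds named here, no measured step involves 4-phenylphenyl; the steps that bear on this change are those that exchange the group on the carbonyl carbon, namely an at least 1.9-fold higher number from compound 1 to compound 2 (0.28 log units; that floor lies within the scatter) together with the two steps already named, and each of them stays within the scatter or at a floor that lies within it. Exchanging the group on the carbonyl carbon has so far moved the number little in this assay. Compound 4 is therefore expected to give a number close to that of compound 3. The expected step is a 1.1-fold higher number from compound 3 to compound 4 (0.04 log units; within the scatter), within the scatter. The estimate for compound 4 in this assay is 70000 nM, with a range from 30000 nM to 160000 nM.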

Compound 4, half-maximal inhibitory concentration: > 100000 nM
Compound 4: only a limit was reported (the forecaster's own chance of this, stated with the estimate: 35%); middle value at least 1.4-fold (0.15 log units) away from the limit.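

In this assay compound 4 gives only a limit of the assay, not a number, as compound 2 does: the limit of > 100000 nM in this assay, at which 2 of the 4 values shown sit. On the carbonyl carbon, 4-phenylphenyl brings an at least 1.5-fold higher number from compound 3 to compound 4 (0.19 log units; that floor lies within the scatter) and an at least 1.9-fold higher number from compound 1 to compound 4 (0.28 log units; that floor lies within the scatter), so even this much larger group, with two six-membered aromatic rings of carbon only, shifts the result by no more than a floor within the scatter. The position now holds two groups that give a limit, 4-methoxyphenyl and 4-phenylphenyl, and two that give a number, thiophen-2-yl and 3,4-difluorophenyl, while the step between the two limits cannot be read.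

On these data alone, how far compound 2 and compound 4 lie beyond the limit stays open. So does whether an amine, a carboxylic acid or a short alkyl chain on the carbonyl carbon would move the number more than these aromatic groups do.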